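The compounds below may be only part of what the source reports. "The series", "measured", "known", "first", "only" and "open" are said of these compounds alone.

Compound 2 `CCCCN(CC1OC(OC2C(N)CC(N)C(OC3OC(CN)C(O)C(O)C3N)C2O)C(O)C(N)C1O)C(C)=O` has been tested in an assay on isolated protein for inhibition of Acyl-protein thioesterase 1 (Rattus norvegicus) (on this read-out lower numbers stand for stronger inhibition and higher numbers for weaker inhibition), where compound 2 gives 109000 nM. Within the data shown here, the only other measured compound, compound 1 `CCCC(=O)N(C)CC1OC(OC2C(N)CC(N)C(OC3OC(CN)C(O)C(O)C3N)C2O)C(O)C(N)C1O`, gives 115000 nM in this assay. The two structures differ only in how the carbons are shared between the amide chain and the chain on the amide nitrogen, and that change gave a 1.1-fold lower number from compound 1 to compound 2 (0.02 log units; within the scatter), so the two numbers sit within the scatter of each other and neither compound can be called the stronger. Compound 3 `CCCCCC(=O)N(CCCC)CC1OC(OC2C(N)CC(N)C(OC3OC(CN)C(O)C(O)C3N)C2O)C(O)C(N)C1O` differs from compound 2 by butyl in place of hydrogen on a saturated chain carbon bound to a carbonyl carbon, which reads, taken one bond further out, as acetyl to pentylcarbonyl. Among the measured compounds shown here, the one measured step bears on this only loosely: rearranging carbons around the same amide left the read-out unchanged. No step beyond the scatter is therefore expected in this assay. Compound 3 is expected to show a 1.1-fold lower number from compound 2 to compound 3 (0.06 log units; within the scatter). Compound 3 is estimated at 95000 nM, with a likely range from 35000 nM to 260000 nM.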

Compound 3, half-maximal inhibitory concentration: 110000 nM
For compound 3 the middle estimate is 1.2-fold (0.06 log units) below the measured one; the measured number falls inside the stated range.
By their numbers in this assay, from the lowest: compounds 2, 3 and 1 (each within the scatter of the next).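

Putting butyl in place of hydrogen on a saturated chain carbon bound to a carbonyl carbon gave a 1.0-fold higher number from compound 2 to compound 3 (0.00 log units; within the scatter) in this assay, so this position accepts a much longer chain without any readable effect on the number, something the earlier swap of carbons around the amide could not show. The larger overall difference tells the same story, with a group of 12 heavy atoms in place of one of 7 giving a 1.0-fold lower number from compound 1 to compound 3 (0.02 log units; within the scatter), so the three compounds cannot be ranked. Nothing measured here offers an explanation for this flat result.

Still open, going by these compounds, is whether any group at this position can move the number beyond the scatter. A chain longer than pentylcarbonyl, or one ending in an amine or a carboxylic acid, would test that.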